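The source may report more compounds than this note shows. Statements on the series, on what has been measured and on what is new or still open speak of the compounds shown alone.

Measured compounds:
compound 1 `Fc1ccc(C2CC(c3ccccc3)=NN2c2ccc(-c3ccccc3)nn2)cc1` – 89200 nM
compound 2 `FC(F)(F)c1ccc(C2CC(c3ccccc3)=NN2c2ccc(-c3ccccc3)nn2)cc1` – 9160 nM
compound 3 `COc1ccc(C2CC(c3ccccc3)=NN2c2ccc(-c3ccccc3)nn2)cc1` – 91700 nM

In a functional assay on A549 cells (Homo sapiens) for antiproliferative activity, read by MTT assay, with a stated time of 24 h (on this read-out higher numbers stand for weaker inhibition and lower numbers for stronger inhibition), compound 3 gives the highest number of the three. Its value and that of compound 1 cannot be told apart, since a 1.0-fold higher number from compound 1 to compound 3 (0.01 log units; within the scatter); compound 2 sits clearly lower, with a 10-fold higher number from compound 2 to compound 3 (1.00 log units; beyond the scatter). For the measured compounds named here, the only steps measured so far swap the group on the first six-membered ring: a 9.7-fold lower number from compound 1 to compound 2 (0.99 log units; beyond the scatter) and a 10-fold higher number from compound 2 to compound 3 (1.00 log units; beyond the scatter).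

Compound 4 `COc1ccc(C2CC(c3ccc(Cl)cc3)=NN2c2ccc(-c3ccccc3)nn2)cc1` is made from compound 3 by a different kind of change: chloro in place of hydrogen on an aromatic carbon. Going by the values given here, none of the measured steps touches this part of the molecule, so there is no measured step that bears on it directly. With nothing in the numbers to point either way, the expectation is that the number for compound 4 stays close to that of compound 3, with no step beyond the scatter: a 1.3-fold lower number from compound 3 to compound 4 (0.12 log units; within the scatter). The value expected for compound 4 in this assay is 70000 nM, with a range from 20000 nM to 200000 nM.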

Compound 4, half-maximal inhibitory concentration: 100000 nM
Estimate against measurement, compound 4: 1.4-fold (0.15 log units) below; measured number inside the range.
By their numbers in this assay, from the lowest: compound 2; then compounds 1, 3 and 4 (each within the scatter of the next).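

The first change away from the ring that carries the methoxy, phenyl to 4-chlorophenyl, gives a 1.1-fold higher number from compound 3 to compound 4 (0.04 log units; within the scatter) in this assay. Adding a single chloro here, para to a large group, therefore leaves the number indistinguishable from before, at least when methoxy is the group on the other ring, whereas the swap of groups on that other ring gave a 9.7-fold lower number from compound 1 to compound 2 (0.99 log units; beyond the scatter) in the same test. Nothing measured here offers an explanation for this result.

For the compounds shown here, it remains open whether chloro would behave the same way alongside the trifluoromethyl of compound 2, the one compound that stands clearly apart. Also open, as far as these compounds go, is whether a different group at this place, such as an amine or a carboxylic acid, would shift the number.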